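The source may report more compounds than this note shows. Statements on the series, on what has been measured and on what is new or still open speak of the compounds shown alone.

Compound 1 `Cn1cc(SCc2nnc(SCc3ccccc3)n2-c2c(Cl)cccc2Cl)c2ccccc21` — in a toxicity assay on HEK-293T cells (Homo sapiens) for cytotoxicity, read by CCK-8 assay, with a stated time of 48 h (a lower number here means that less compound is tolerated, a higher number that more compound is tolerated), compound 1 gives > 100000 nM
Compound 2 `Cn1cc(SCc2nnc(SCc3ccc(Cl)cc3Cl)n2-c2c(Cl)cccc2Cl)c2ccccc21` — in this assay compound 2 gives > 100000 nM

Compound 1 stands only at a limit in this assay: the value > 100000 nM for compound 1 is a limit of the assay, not a number. The value for compound 2, > 100000 nM, is likewise a limit of the assay. Both shown values sit at the same limit (the limit of > 100000 nM in this assay, at which 2 of the 2 values shown sit). Going by the values given here, the single measured step, a step that the two limits leave unreadable from compound 1 to compound 2, is thus left unreadable between two limits; it is the only step available, and it alters the same place, the saturated chain carbon bound to a sulfur.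

Compound 3 `Cn1cc(SCc2nnc(SCc3c(F)cccc3Cl)n2-c2c(Cl)cccc2Cl)c2ccccc21` differs from compound 1 by 2-chloro-6-fluorophenyl in place of phenyl on a saturated chain carbon bound to a sulfur. Among the compounds with values here, no step of readable size exists, so no change beyond the scatter can be expected from compound 1 to compound 3 in this assay, and a further limit is the most likely outcome. Compound 3 is therefore expected to lie at about 150000 nM, with a range from 80000 nM to 400000 nM. This expectation corresponds to a step that the limit leaves unreadable from compound 1 to compound 3.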

Compound 3, half-maximal cytotoxic concentration: > 100000 nM
Compound 3: no number, only a limit; the forecaster's own chance of this, stated with the estimate: 85%; the middle value lies beyond the limit too.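

In this assay compound 3 gives > 100000 nM, which is a limit of the assay and not a number. The steps from compound 1 and compound 2 to compound 3 therefore cannot be read, for all three compounds share one limit: the limit of > 100000 nM in this assay, at which 3 of the 3 values shown sit. The compounds shown leave open whether phenyl, 2,4-dichlorophenyl and 2-chloro-6-fluorophenyl differ at all in this assay.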